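A few compounds are considered here, and "the series" means these few. Any claim that something is new, unique, unknown or untested is made for them only; others in the source may bear on it.

Working notes on the series in an ADME assay on THP-1 cells (Homo sapiens) for cytotoxicity, read by MTT assay; on this read-out lower numbers stand for higher toxicity in this test and higher numbers for lower toxicity in this test.

Compound 1 `Cc1nc(-c2cccnc2)sc1-c1nnc(-c2ccc(Br)cc2)o1` and compound 2 `Cc1cccc(-c2nnc(-c3sc(-c4cccnc4)nc3C)o2)c1` share one core and differ only in the aryl group on it. In this assay compound 1 gives > 100 ug/mL, which is a limit of the assay and not a number. In this assay compound 2 likewise gives > 100 ug/mL, also a limit and not a number. The step that the two limits leave unreadable from compound 1 to compound 2 therefore cannot be read in size; all that is known is the limit of > 100 ug/mL in this assay, at which 2 of the 2 values shown sit, so compound 2 stands at that limit and no higher or lower position can be assigned to it.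

Compound 3 `Cc1ccc(-c2nnc(-c3sc(-c4cccnc4)nc3C)o2)cc1` is the next member, differing from compound 2 by 4-methylphenyl in place of 3-methylphenyl on an aromatic carbon. Among the compounds with values here, no measured step bears on this change in a readable way, since the only step in hand is unreadable. The expected step of a number no higher from compound 2 to compound 3 (the limit leaves the size open) is therefore none beyond the scatter. Compound 3 is estimated at 100 ug/mL, within 50 ug/mL to 200 ug/mL, most likely reported again as a limit.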

Compound 3, half-maximal cytotoxic concentration: > 100 ug/mL
Compound 3: a limit, no number; the forecaster's own chance of this, stated with the estimate: 80%; the middle value lies on the limit itself.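

In this assay compound 3 gives > 100 ug/mL, a limit of the assay and not a number. No new step can be read among compound 1, compound 2 and compound 3. The compounds shown leave open whether the aryl changes alter the read-out at all, with every value at one limit: the limit of > 100 ug/mL in this assay, at which 3 of the 3 values shown sit.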